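N-methylation of the bicyclic diamine in a chemokine receptor antagonist

The compounds below may be only part of what the source reports. "The series", "measured", "known", "first", "only" and "open" are said of these compounds alone.

Measured compounds:
compound 1 `CN(C[C@H]1Cc2c(cccc2N2CCC(N)CC2)CN1)[C@H]1CCCc2cccnc21` gives 33.4 nM
compound 2 `CN(C[C@H]1Cc2c(cccc2N2C[C@H]3CNC[C@H]3C2)CN1)[C@H]1CCCc2cccnc21` gives 10.3 nM

Both compounds were tested in a functional assay on CCRF-CEM cells for antagonist activity at C-X-C chemokine receptor type 4 (Homo sapiens), read by calcium flux, with stated times of 25 min and 90 s; on this read-out higher numbers stand for weaker inhibition and lower numbers for stronger inhibition. Among the compounds with values here, compound 2 carries the lower of the two numbers; the only measured step, a 3.2-fold lower number from compound 1 to compound 2 (0.51 log units; beyond the scatter), separates it from compound 1.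

Compound 3 `CN1CC[C@H]2CN(c3cccc4c3C[C@H](CN(C)[C@H]3CCCc5cccnc53)NC4)C[C@H]21` is derived from compound 2 by a change on an aromatic carbon: a group of 9 heavy atoms (7 carbon, 2 nitrogen; 2 five-membered non-aromatic rings with 1 hetero atom each) in place of a group of 8 heavy atoms (6 carbon, 2 nitrogen; 2 five-membered non-aromatic rings with 1 hetero atom each), on an aromatic carbon. The group that enters keeps the same two five-membered non-aromatic rings, but the hydrogen-bond donor of compound 2 is gone.

Within the data shown here, no measured step addresses this change. Among the measured compounds shown here, the only step on record, a 3.2-fold lower number from compound 1 to compound 2 (0.51 log units; beyond the scatter), alters the ring system itself rather than a substituent on it, so it offers no direct guide. The change from compound 2 to compound 3 is small, and the number for compound 3 in this assay is therefore expected to stay near that of compound 2, with the expected step of a 1.5-fold higher number from compound 2 to compound 3 (0.16 log units; within the scatter) possibly within the scatter. Compound 3 is estimated at 15 nM, with a range from 5 nM to 45 nM.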

Compound 3, half-maximal inhibitory concentration: 11.4 nM
For compound 3 the middle estimate is 1.3-fold (0.12 log units) above the measured one; measured number inside the range.
By their numbers in this assay, from the lowest: compounds 2 and 3 (each within the scatter of the next); then compound 1.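

In this assay, the step of a 1.1-fold higher number from compound 2 to compound 3 (0.04 log units; within the scatter) shows that, at this place on an aromatic carbon, a group with 0 hydrogen-bond donors and one more carbon can take the place of the group with 1 hydrogen-bond donor without moving the number beyond the scatter. The earlier compounds shown here could not show this, and the step of a 2.9-fold lower number from compound 1 to compound 3 (0.47 log units; beyond the scatter) now shows that compound 3, like compound 2, stands apart from compound 1, so two different groups with two five-membered non-aromatic rings each give lower numbers than the group with one six-membered non-aromatic ring. No measurement at hand explains why the hydrogen-bond donor can go with so little effect on this number.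

The compounds shown leave open whether a larger group in place of the methyl, such as an ethyl, a benzyl or an acetyl, would keep the number in this range. They also leave open whether a primary amine or a carboxylic acid on the same two-ring group would do so, and whether the pattern holds in any read-out other than this assay.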